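The compounds below may be only part of what the source reports. "The series", "measured", "known", "first", "only" and "open" are said of these compounds alone.

The measured compounds in an assay on membranes from brain for binding affinity to Neuronal acetylcholine receptor; alpha4/beta2 (Rattus norvegicus) (on this read-out higher numbers stand for weaker inhibition and lower numbers for stronger inhibition), are:

- compound 1, `Cc1ccccc1-c1cncc(OC[C@@H]2CCCN2C)c1`: 1.1 nM
- compound 2, `CN1CCC[C@H]1COc1cncc(-c2ccccc2C=O)c1`: 0.56 nM
- compound 3, `CN1CCC[C@H]1COc1cncc(-c2cccc(N)c2)c1`: 0.43 nM

Compound 3 gives the smallest of the three numbers; compound 2 lies within the scatter of it, and only compound 1 stands apart, by the step of a 2.6-fold lower number from compound 1 to compound 3 (0.41 log units; beyond the scatter). Compound 4, `CN1CCC[C@H]1COc1cncc(-c2ccc(Cl)cc2)c1`, differs from compound 3 by 4-chlorophenyl in place of 3-aminophenyl on an aromatic carbon. One measured step exchanges this aromatic group, a 2.6-fold lower number from compound 1 to compound 3 (0.41 log units; beyond the scatter), and it was modest; the other, a 2.0-fold lower number from compound 1 to compound 2 (0.29 log units; within the scatter), alters a substituent on that ring and stays within the scatter. The aryl exchanges seen so far moved the numbers little, so compound 4 is expected to shift only slightly, if at all, by a 3.5-fold higher number from compound 3 to compound 4 (0.54 log units; beyond the scatter). Compound 4 is therefore estimated at 1.5 nM in this assay, between 0.5 nM and 5 nM.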

Compound 4, inhibition constant: 0.082 nM
For compound 4 the middle estimate is 18-fold (1.26 log units) above the measured one; the measured number lies below the stated range.
By their numbers in this assay, from the lowest: compound 4; then compounds 3, 2 and 1 (each within the scatter of the next, the first and the last beyond it).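

In this assay, within the data shown here, the aryl group at this position matters more than the earlier compounds showed: 4-chlorophenyl brings a 5.2-fold lower number from compound 3 to compound 4 (0.72 log units; beyond the scatter) against 3-aminophenyl and a 13-fold lower number from compound 1 to compound 4 (1.13 log units; beyond the scatter) against 2-methylphenyl, the first large step. The low number also comes with the hydrogen-bond donor and acceptor of 3-aminophenyl gone, so neither is required for it here. No evidence is available that accounts for this gain. Still open is whether the chlorine itself or its place on the ring carries the step, as the compounds shown include no amine at the chlorine's place and no chlorine at the amine's. On these data alone, how a bromine or a methoxy group would compare at that place also remains open.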